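Replacing a Difluorophenyl Group: Expected Effect on Cell Growth

The source may report more compounds than this note shows. Statements on the series, on what has been measured and on what is new or still open speak of the compounds shown alone.

Measured so far in a functional assay on BCG823 cells (Homo sapiens) for inhibition, read by MTT assay, with a stated time of 72 h; on this read-out lower numbers stand for stronger inhibition and higher numbers for weaker inhibition:
Compound 1, `CN(C(=O)NC(=O)c1ccc([N+](=O)[O-])cc1)c1nc(C(F)(F)F)c(C(=O)N/N=C/c2ccc([N+](=O)[O-])cc2)s1`, gives 7.45 ug/mL.
Compound 2, `CNc1nc(C)c(C(=O)N/N=C/c2cc(C(F)(F)F)cc(C(F)(F)F)c2)s1`, gives only a limit of the assay, > 100 ug/mL.
Compound 3, `CN(C(=O)NC(=O)c1ccc(F)c(F)c1)c1nc(C(F)(F)F)c(C(=O)N/N=C/c2cc(C(F)(F)F)cc(C(F)(F)F)c2)s1`, gives 3.51 ug/mL.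

Of the two numbers shown, compound 3 has the lowest; the nearest is compound 1, whose gap lies beyond the usual scatter. Compound 4, `CN(C(=O)NC(=O)c1cccc(C(F)(F)F)c1)c1nc(C(F)(F)F)c(C(=O)N/N=C/c2cc(C(F)(F)F)cc(C(F)(F)F)c2)s1`, differs from compound 3 by 3-(trifluoromethyl)phenyl in place of 3,4-difluorophenyl on a carbonyl carbon. Going by the values given here, no measured pair shows this change, so its direction is unknown from these data. The expected step is a 1.1-fold higher number from compound 3 to compound 4 (0.06 log units; within the scatter), which is within the scatter. Compound 4 is expected to give about 4 ug/mL in this assay. The range expected for compound 4 runs from 1.5 ug/mL to 12 ug/mL.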

Compound 4, half-maximal inhibitory concentration: 5.23 ug/mL
Compound 4: middle estimate off by 1.3-fold (0.12 log units), on the low side; measured number inside the range.
By their numbers in this assay, from the lowest: compounds 3, 4 and 1 (each within the scatter of the next, the first and the last beyond it). At a limit, above all of these: compound 2.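

Going by these compounds alone, this is the first pair of compounds that differ only at this place, the group on the carbonyl carbon: 3-(trifluoromethyl)phenyl in place of 3,4-difluorophenyl gives a 1.5-fold higher number from compound 3 to compound 4 (0.17 log units; within the scatter) in this assay. The two fluorinated phenyl groups therefore cannot be told apart in this assay, so the position accepts either one. Nothing measured here accounts for this similarity. Still open, from the compounds shown here alone, is whether a plain phenyl ring without fluorine would match them. Going by these compounds, it is also open whether a group of a different kind, such as an amine or a longer carbon chain, would hold up here.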